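Working notes: chloro to trifluoromethoxy on the aryl ring

A few compounds are considered here, and "the series" means these few. Any claim that something is new, unique, unknown or untested is made for them only; others in the source may bear on it.

Measured so far:
compound 1 `O=C(O)CCNC(=O)c1ccc(CC(c2ccc(OC(F)(F)F)cc2)c2nc(-c3ccc(Cl)cc3)cs2)cc1`: 316 nM
compound 2 `O=C(O)CCNC(=O)c1ccc(CN(c2ccc(Cl)cc2)c2nc(-c3ccc(C(F)(F)F)cc3)cs2)cc1`: 649 nM

In an in vitro assay on BHK cells for displacement of a labelled ligand from gastric inhibitory polypeptide receptor (Homo sapiens), read by scintillation proximity assay (a higher number here means a weaker inhibitor, a lower number a stronger inhibitor), compound 2 stands highest of the two numbers; its nearest neighbour is compound 1, which gives a lower number, a gap that lies beyond the usual scatter. Among the compounds with values here, the two compounds differ in more than one place, so no single step between them can be read.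

Compound 3 `O=C(O)CCNC(=O)c1ccc(CN(c2ccc(OC(F)(F)F)cc2)c2nc(-c3ccc(C(F)(F)F)cc3)cs2)cc1` is not yet measured. Compared with compound 2 the change is trifluoromethoxy in place of chloro on an aromatic carbon.

Within the data shown here, no step of this kind has been measured, so the expectation rests on compound 1 carrying a trifluoromethoxy group and giving 316 nM. For compound 3 a modest step towards a lower number is expected, a 1.5-fold lower number from compound 2 to compound 3 (0.19 log units; within the scatter), though a step hidden within the scatter is also possible. Compound 3 is estimated at 420 nM, with a range of 150 nM to 1200 nM.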

Compound 3, half-maximal inhibitory concentration: 833 nM
Estimate against measurement, compound 3: 2.0-fold (0.30 log units) below; low and high end bracket the measured number.
By their numbers in this assay, from the lowest: compound 1; then compounds 2 and 3 (each within the scatter of the next).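

In this assay, within the data shown here, trifluoromethoxy in place of chloro on an aromatic carbon para to a large group gives a 1.3-fold higher number from compound 2 to compound 3 (0.11 log units; within the scatter), so the first single-place step shows that this position takes a group of five heavy atoms in place of one, plus a hydrogen-bond acceptor, with no readable shift in the number. The steps from compound 1 to compound 2 and compound 3 cannot be read, since compound 1 differs from each in more than one place. No measurement of any property accompanies this step, so it carries no explanation.

Open, on these data alone, is how an amine, a nitrile or a carboxylic acid would read at this same position. Also open, as far as these compounds go, is what the same exchange does when the rest of the core matches compound 1 rather than compound 2.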